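The source may hold more compounds than are shown below. What is called first, only, known or untested is meant among the compounds shown, and "the series" means these compounds.

Going by the values given here, compound 2, whose structure is `COc1ccc(C(=O)/C=C/c2cc(-c3cc(OC)c(OC)c(OC)c3)n[nH]2)cc1`, is one of two compounds measured in a functional assay on NCI-H23 cells (Homo sapiens) for cytotoxicity, read by sulforhodamine B assay, with a stated time of 48 h, tested at 100 uM; on this read-out lower numbers stand for a stronger effect and higher numbers for a weaker effect at the one concentration tested. There compound 2 gives -23%, the highest of the two numbers. Its nearest neighbour is compound 1, built as `COc1ccc(C(=O)/C=C/c2cc(-c3cc(OC)c(OC)c(OC)c3)n[nH]2)cc1OC`, which in this assay gives -75%. Among the compounds with values here, the only step between measured compounds, a number 52 percentage points higher from compound 1 to compound 2 (beyond the scatter), came with hydrogen in place of methoxy on an aromatic carbon, a large step beyond the scatter.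

Compound 3, drawn as `COc1cc(-c2cc(/C=C/C(=O)c3ccc(F)c(F)c3)[nH]n2)cc(OC)c1OC`, has not yet been measured in this assay. It differs from compound 2 in this way: 3,4-difluorophenyl in place of 4-methoxyphenyl on a carbonyl carbon. Within the data shown here, no measured step bears on this exact change; the step from compound 1 to compound 2 altered the same aromatic ring, and it weakened the effect, but it removed a methoxy rather than exchanging the whole ring. The step of a number 18 percentage points higher from compound 2 to compound 3 (beyond the scatter) is therefore expected to be small, with no change beyond the scatter as the most likely outcome. Compound 3 is accordingly estimated to give -5% in this assay, within a range from -45% to 25%.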

Compound 3, a percentage reported as activity, at one concentration (the size of the read-out at that concentration, not a potency): -27%
Beside the measured number, compound 3's estimate is 22 percentage points above it; low and high end bracket the measured number.
By their numbers in this assay, from the lowest: compound 1; then compounds 3 and 2 (each within the scatter of the next).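

In this assay, exchanging the whole 4-methoxyphenyl for 3,4-difluorophenyl on the carbonyl carbon gives a number 4 percentage points lower from compound 2 to compound 3 (within the scatter) and so leaves the read-out within the usual scatter, which shows that this position accepts a ring with fluorine in place of methoxy and with no hydrogen-bond acceptor counted on it, without a reading apart from compound 2. Set against 3,4-dimethoxyphenyl, the same 3,4-difluorophenyl gives a number 48 percentage points higher from compound 1 to compound 3 (beyond the scatter) and this large step shows that two substituents on the ring in that arrangement are not enough in themselves to match compound 1, which stands as the strongest of the three at the one concentration tested. The earlier pair could not show this, since its single step only removed a methoxy, while here compound 1 alone stands apart and nothing shown gives a reason for the result.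

On these data alone, whether a 3,4-dihydroxyphenyl or a 3,4-dichlorophenyl on this carbonyl carbon would read like compound 1 or like compounds 2 and 3 stays open. So does whether a lone 3-methoxyphenyl would behave as the 4-methoxyphenyl of compound 2 does.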